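Swapping the Sulfonamide Amine: From Compound 2 to Compound 4

The source may report more compounds than this note shows. Statements on the series, on what has been measured and on what is new or still open speak of the compounds shown alone.

Of the compounds shown here, three that share a common core have been tested in an assay on CHO cells for displacement of a labelled ligand from prostaglandin D2 receptor 2 (Homo sapiens), read by scintillation counting; on this read-out lower numbers stand for stronger inhibition and higher numbers for weaker inhibition. Compound 1 `CN(C)S(=O)(=O)c1ccc(F)c(C#Cc2cc(Cl)ccc2OCC(=O)O)c1` gives 3.1 nM. Compound 2 `COCCN(C)S(=O)(=O)c1ccc(C)c(C#Cc2cc(Cl)ccc2OCC(=O)O)c1` gives 4.1 nM, a number that lies within the usual scatter of the value for compound 1. Compound 3 `CN(C)S(=O)(=O)c1cncc(C#Cc2cc(Cl)ccc2OCC(=O)O)c1` gives 37 nM, a higher number than compound 2 and beyond the scatter. Compound 2 therefore stands together with compound 1 among the lower numbers of this small set, well apart from compound 3.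

Compound 4 `Cc1ccc(S(=O)(=O)NC(C)C)cc1C#Cc1cc(Cl)ccc1OCC(=O)O` has not yet been measured. It differs from compound 2 by isopropylamino in place of (2-methoxyethyl)(methyl)amino on a sulfonyl sulfur. For the measured compounds named here, no pair of measured compounds shows this particular change, so there is no measured step to lean on. Given that the measured compounds vary in other places without a step of this kind to compare, the expected step from compound 2 to compound 4 is a 1.2-fold higher number from compound 2 to compound 4 (0.09 log units; within the scatter), which lies within the scatter. Compound 4 is estimated at 5 nM, with a range from 2 nM to 15 nM.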

Compound 4, inhibition constant: 3.4 nM
Compound 4: middle estimate off by 1.5-fold (0.17 log units), on the high side, within the range that was stated.
By their numbers in this assay, from the lowest: compounds 1, 4 and 2 (each within the scatter of the next); then compound 3.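

In this assay, for the compounds shown here, exchanging the amine on the sulfonyl sulfur gives a 1.2-fold lower number from compound 2 to compound 4 (0.08 log units; within the scatter), the first measured step for a change at this place. Isopropylamino brings a hydrogen-bond donor and does away with the hydrogen-bond acceptor and the longer chain of (2-methoxyethyl)(methyl)amino, yet the numbers for this pair cannot be told apart, so on this core the sulfonyl sulfur can carry either amine with no difference beyond the scatter. Nothing at hand explains why these two amines read alike. Going by these compounds, this is a single pair, so whether the same exchange would read alike on the core of compound 1 or compound 3 remains open. Also open, on these data alone, is how a ring amine such as morpholine, or a plain unsubstituted amino group, would read on the sulfonyl sulfur.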